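Working notes: stability series, the step from compound 3 to compound 4

The compounds below may be only part of what the source reports. "The series", "measured", "known", "first", "only" and "open" are said of these compounds alone.

Measured so far:
- compound 1 `Cc1oc(=O)oc1COC(=O)c1cccc(NC(=O)[C@@H]2C[C@H](SC3=C(C(=O)O)N4C(=O)[C@H]([C@@H](C)O)[C@H]4[C@H]3C)CN2)c1` — in an ADME assay for metabolic stability, read by LC-MS, with a stated time of 3 h, at pH 6.5, tested at 50 uM (on this read-out lower numbers stand for a less stable compound and higher numbers for a more stable compound), compound 1 gives > 95%
- compound 2 `C[C@@H](O)[C@H]1C(=O)N2C3=C(S[C@@H]4CN[C@@H](C4)C(=O)Nc4cccc(c4)C(=O)OCOCOC3=O)[C@H](C)[C@H]12` — in this assay compound 2 gives > 95%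
- compound 3 `CCOC(=O)C1=C(S[C@@H]2CN[C@H](C(=O)Nc3cccc(C(=O)OCC)c3)C2)[C@H](C)[C@@H]2[C@@H]([C@@H](C)OC(C)=O)C(=O)N12` — in this assay compound 3 gives > 95%

The value of compound 1 is a limit of the assay, not a number. The value of compound 2 is likewise a limit. The value of compound 3 is also a limit, so compound 3 cannot be placed within the measured set beyond the limit itself; all three values shown sit there (the limit of > 95% in this assay, at which 3 of the 3 values shown sit).

Compound 4 `CCOC(=O)C1=C(S[C@@H]2CN[C@H](C(=O)Nc3cccc(C(=O)OCC)c3)C2)[C@H](C)[C@@H]2[C@@H]([C@@H](C)O)C(=O)N12` differs from compound 3 in one place: hydrogen in place of acetyl on an oxygen on a saturated carbon, the change reading as acetoxy to hydroxy at the next bond out. For the measured compounds named here, no step between measured compounds is available, so the size of the effect of this change in this assay cannot be read from the data.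

The expectation is that the step of a number no higher from compound 3 to compound 4 (the limit leaves the size open) stays within the scatter, because compound 1 gives > 95% with the hydroxy form present. The estimate for compound 4 in this assay is 95%, with a range from 85% to 100%, and most likely the assay again reports only the limit.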

Compound 4, percent of the compound remaining: > 95%
Compound 4 gave a limit, no number; the forecaster's own chance of this, stated with the estimate: 70%; the middle value lies on the limit itself.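

Compound 3 and compound 4 both give a limit of the assay rather than a number, so no step between them can be read: the limit of > 95% in this assay, at which 4 of the 4 values shown sit.

The compounds shown leave open whether the change from acetoxy to hydroxy alters the result in this assay at all, and how the four compounds would rank there.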